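The compounds below may be only part of what the source reports. "The series", "measured", "known", "first", "only" and "open" are said of these compounds alone.

Compound 1 `COc1cc2ncnc(Nc3ccc(Cl)cc3)c2cc1OCCCCC(=O)Nc1ccc(S(N)(=O)=O)cc1`: > 40000 nM
Compound 2 `NS(=O)(=O)c1ccc(NC(=S)Nc2ccc3ncnc(Nc4cccc(Br)c4)c3c2)cc1`: 25000 nM

In a functional assay on A549 cells (Homo sapiens) for antiproliferative activity, read by MTT assay, with a stated time of 72 h (on this read-out lower numbers stand for stronger inhibition and higher numbers for weaker inhibition), compound 1 gives > 40000 nM, which is a limit of the assay and not a number. Within the data shown here, compound 2 gives 25000 nM in this assay, the only measured number here, since the other value sits at the limit of > 40000 nM in this assay, at which 1 of the 2 values shown sits. Compound 3 `Cc1cccc(Nc2ncnc3ccc(NC(=S)Nc4ccc(S(N)(=O)=O)cc4)cc23)c1` differs from compound 2 by one change: methyl in place of bromo on an aromatic carbon. Among the measured compounds shown here, no pair of measured compounds shows this kind of change. No step beyond the usual scatter is expected from it in either direction. Compound 3 is therefore estimated at 25000 nM, between 9000 nM and 70000 nM, an expected step of no change at the digits printed from compound 2 to compound 3 (within the scatter).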

Compound 3, half-maximal inhibitory concentration: > 40000 nM
Compound 3: only a limit was reported; the forecaster's own chance of this, stated with the estimate: 30%; at least 1.6-fold (0.20 log units) between middle value and limit.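

The change of bromo to methyl on this aromatic carbon gives an at least 1.6-fold higher number from compound 2 to compound 3 (0.20 log units; that floor lies within the scatter) in this assay. On these data alone, compound 3 reads > 40000 nM, which is a limit of the assay and not a number, so the true size of the step stays unknown and methyl shows no sign of improving on bromo here. The limit now holds most of the compounds shown: the limit of > 40000 nM in this assay, at which 2 of the 3 values shown sit.

Still open, as far as these compounds go, is whether fluoro, an amine or a nitrile at this place would give a lower number than compound 2. The numbers shown also cannot tell how far compound 3 lies past the limit.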